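The source may hold more compounds than are shown below. What is called first, only, known or untested is meant among the compounds shown, and "the series" means these compounds.

Three compounds share one core and differ only in the group on a saturated chain carbon bound to an oxygen on an aromatic ring. In a functional assay for inhibition, with Homo sapiens as the target (on this read-out higher numbers stand for weaker inhibition and lower numbers for stronger inhibition), compound 1 `CC(C)(C)Sc1c(CC(C)(C)C(=O)O)n(Cc2ccc(Cl)cc2)c2ccc(OCc3ccc4cc(F)ccc4n3)cc12` gives 2 nM, compound 2 `CC(C)(C)Sc1c(CC(C)(C)C(=O)O)n(Cc2ccc(Cl)cc2)c2ccc(OCc3nc4ccccc4s3)cc12` gives 3 nM, and compound 3 `COc1ccc2nc(COc3ccc4c(c3)c(SC(C)(C)C)c(CC(C)(C)C(=O)O)n4Cc3ccc(Cl)cc3)sc2c1` gives 8 nM, the highest number of the three. The untested compound 4 `CC(C)(C)Sc1c(CC(C)(C)C(=O)O)n(Cc2ccc(Cl)cc2)c2ccc(OCc3ccncc3)cc12` carries pyridin-4-yl in place of the 6-methoxy-1,3-benzothiazol-2-yl of compound 3: pyridin-4-yl in place of 6-methoxy-1,3-benzothiazol-2-yl on a saturated chain carbon bound to an oxygen on an aromatic ring.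

Among the compounds with values here, no measured step goes to a group this small, so the evidence is indirect. Exchanging one large group for another gave a 1.5-fold higher number from compound 1 to compound 2 (0.18 log units; within the scatter), adding methoxy gave a 2.7-fold higher number from compound 2 to compound 3 (0.43 log units; beyond the scatter), and the two changes of group taken together gave a 4.0-fold higher number from compound 1 to compound 3 (0.60 log units; beyond the scatter). These steps are modest at most, but the coming change removes more of the group than any of them. The step expected in this assay is therefore a 2.5-fold higher number from compound 3 to compound 4 (0.40 log units; beyond the scatter), a modest one towards weaker inhibition. For compound 4 the estimated value is 20 nM, with an expected range of 5 nM to 80 nM.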

Compound 4, half-maximal inhibitory concentration: 6 nM
Estimate against measurement, compound 4: 3.3-fold (0.52 log units) above, and the stated range covers the measured number.
By their numbers in this assay, from the lowest: compounds 1, 2, 4 and 3 (each within the scatter of the next, the first and the last beyond it).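

Within the data shown here, this position accepts a much smaller group than the earlier compounds showed: in this assay, exchanging the 11 heavy atoms and two rings of 6-methoxy-1,3-benzothiazol-2-yl for the 6 heavy atoms and single ring of pyridin-4-yl gives a 1.3-fold lower number from compound 3 to compound 4 (0.12 log units; within the scatter). The same exchange starting from the unsubstituted 1,3-benzothiazol-2-yl gives a 2.0-fold higher number from compound 2 to compound 4 (0.30 log units; within the scatter), so neither of these two larger groups is needed to keep the number at this level. Only 6-fluoroquinolin-2-yl separates from pyridin-4-yl, with a 3.0-fold higher number from compound 1 to compound 4 (0.48 log units; beyond the scatter), and that step is still modest.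

Nothing shown gives a reason for this tolerance. A phenyl ring, pyridin-2-yl or a simple methyl group at this place would test whether the ring nitrogen or the ring itself matters at all.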